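Compound 3 and the Thiophene Swap

This account rests on a few compounds, and the source may have more. Where it says the series, first, only, none or still open, it means among the compounds named here.

Compound 1 `COc1cccc(-c2nc3cccc(-c4cc(OC)c(OC)c(OC)c4)c3o2)c1`: 3500 nM
Compound 2 `COc1cc(-c2cccc3nc(-c4ccc(Cl)cc4)oc23)cc(OC)c1OC`: 5600 nM
Compound 3 `COc1cc(-c2cccc3nc(-c4cccc(O)c4)oc23)cc(OC)c1OC`: 2000 nM

The low end of the numbers in a functional assay on A549 cells (Homo sapiens) for antiproliferative activity, read by MTT assay, with a stated time of 48 h (on this read-out higher numbers stand for weaker inhibition and lower numbers for stronger inhibition), is where compound 3 stands. Of the two steps that reach it, a 2.8-fold lower number from compound 2 to compound 3 (0.45 log units; beyond the scatter) passes the scatter, while a 1.8-fold lower number from compound 1 to compound 3 (0.24 log units; within the scatter) stays within it. Compound 4 `COc1cc(-c2cccc3nc(-c4cccs4)oc23)cc(OC)c1OC` is still unmeasured. Its change is thiophen-2-yl in place of 3-hydroxyphenyl on an aromatic carbon: thiophen-2-yl in place of 3-hydroxyphenyl, on an aromatic carbon next to the ring nitrogen and next to the ring oxygen. For the measured compounds named here, no measured compound carries thiophen-2-yl, so the evidence is indirect. Another replacement at this carbon gave a 1.6-fold higher number from compound 1 to compound 2 (0.20 log units; within the scatter). A small expected move towards a higher number in this assay, probably not beyond the scatter, is a 1.8-fold higher number from compound 3 to compound 4 (0.24 log units; within the scatter). Compound 4 is estimated at 3500 nM, with an expected range from 1300 nM to 9000 nM.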

Compound 4, half-maximal inhibitory concentration: 12500 nM
Estimate against measurement, compound 4: 3.6-fold (0.55 log units) below, and the stated range ends below it.
By their numbers in this assay, from the lowest: compounds 3, 1 and 2 (each within the scatter of the next, the first and the last beyond it); then compound 4.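

In this assay, every step to the thiophen-2-yl compound goes beyond the scatter: a 6.3-fold higher number from compound 3 to compound 4 (0.80 log units; beyond the scatter), a 3.6-fold higher number from compound 1 to compound 4 (0.55 log units; beyond the scatter) and a 2.2-fold higher number from compound 2 to compound 4 (0.35 log units; beyond the scatter). This makes compound 4 the weakest of the four, so a five-membered sulfur ring at this carbon costs more than any exchange among the substituted phenyl groups did. Nothing measured here explains this loss. The compounds shown leave open whether furan-2-yl at this carbon would follow thiophen-2-yl, and whether a phenyl ring carrying an amine would match 3-hydroxyphenyl.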